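Adding a methyl group to compound 1

The source may hold more compounds than are shown below. What is called first, only, known or untested is meant among the compounds shown, and "the series" means these compounds.

- Compound 1 `CCCCSc1nc(O)cc(C(C)c2c(F)cccc2F)n1`: > 200000 nM
- Compound 2 `CC(C)CSc1nc(O)cc(C(C)c2c(F)cccc2F)n1`: > 200000 nM

In a functional assay on MT4 cells (Homo sapiens) for cytotoxicity (on this read-out higher numbers stand for lower toxicity in this test and lower numbers for higher toxicity in this test), compound 1 gives > 200000 nM, which is a limit and not a number. Compound 2 gives > 200000 nM, also a limit. This is the limit of > 200000 nM in this assay, at which 2 of the 2 values shown sit. Among the measured compounds shown here, the one measured step, a step that the two limits leave unreadable from compound 1 to compound 2, offers no size to carry over.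

Compound 3 `CCCCSc1nc(O)c(C)c(C(C)c2c(F)cccc2F)n1` differs from compound 1 by one change: methyl in place of hydrogen on an aromatic carbon. With compound 1 at its limit of > 200000 nM, no step beyond the usual scatter is expected in this assay, and another limit is quite possible. The estimated step is a number no higher from compound 1 to compound 3 (the limit leaves the size open). Compound 3 is expected to give 200000 nM, within an estimated range of 90000 nM to 400000 nM.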

Compound 3, half-maximal cytotoxic concentration: 112000 nM
Compound 3: the middle estimate sits 1.8-fold (0.25 log units) above what was measured, and the stated range covers the measured number.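

In this assay, methyl in place of hydrogen on the aromatic carbon ortho to a hydroxy group gives the only true number among these compounds, where the two chain variants gave only limits of the assay. The change is an at least 1.7-fold lower number from compound 1 to compound 3 (0.25 log units; that floor lies within the scatter), so a lower number is seen, although its floor does not clear the usual scatter. The real size stays open because compound 1 is itself only a limit: the limit of > 200000 nM in this assay, at which 2 of the 3 values shown sit.

From the compounds shown here alone, whether ethyl or an amine at this position would lower the number further remains open. So does whether methyl there would act the same way on compound 2.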